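Bromine position and urea aryl change in one series

This account rests on a few compounds, and the source may have more. Where it says the series, first, only, none or still open, it means among the compounds named here.

Compound 1 `COc1cc(Br)ccc1Nc1cc(NC(=O)Nc2c(Cl)cccc2Cl)ncn1` gives 43% in a functional assay on NCI-H226 cells (Homo sapiens) for inhibition, read by MTT assay, with a stated time of 48 h, tested at 10 uM; on this read-out higher numbers stand for more inhibition at the one concentration tested (going by the name of the read-out) and lower numbers for less inhibition. Compound 2 `COc1ccc(Br)cc1Nc1cc(NC(=O)Nc2c(Cl)cccc2Cl)ncn1` carries the change 5-bromo-2-methoxyphenyl in place of 4-bromo-2-methoxyphenyl on a nitrogen on an aromatic ring and gives 33% in this assay; the step is a number 10 percentage points lower from compound 1 to compound 2 (within the scatter). Compound 3 `COc1cc(NC(=O)Nc2cc(Nc3ccc(Br)cc3OC)ncn2)cc(OC)c1` differs from compound 1 by 3,5-dimethoxyphenyl in place of 2,6-dichlorophenyl on an amide-type nitrogen; in this assay compound 3 gives 25.7%, a step of a number 17.3 percentage points lower from compound 1 to compound 3 (beyond the scatter). Compound 4 `COc1cc(NC(=O)Nc2cc(Nc3cc(Br)ccc3OC)ncn2)cc(OC)c1` has not been measured; it differs from compound 3 by 5-bromo-2-methoxyphenyl in place of 4-bromo-2-methoxyphenyl on a nitrogen on an aromatic ring, the same change seen from compound 1 to compound 2, at the same place. Compound 4 is expected to show an estimated step of a number 7.7 percentage points lower from compound 3 to compound 4 (within the scatter) because the same change earlier gave a number 10 percentage points lower from compound 1 to compound 2 (within the scatter). Compound 4 is therefore estimated at 18% in this assay, within a range from 5% to 32%.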

Compound 4, a percentage reported as inhibition, at one concentration (the size of the read-out at that concentration, not a potency): 42.7%
Compound 4: middle estimate off by 24.7 percentage points, on the low side, outside the stated range (above it).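

The change to 5-bromo-2-methoxyphenyl on the core of compound 3 gives a number 17 percentage points higher from compound 3 to compound 4 (beyond the scatter), which does not repeat the earlier step on the core of compound 1: the same change on two cores in this assay, a number 10 percentage points lower (within the scatter) from compound 1 to compound 2 and a number 17 percentage points higher (beyond the scatter) from compound 3 to compound 4, 27 percentage points apart, beyond the scatter of two such steps. The change to 3,5-dimethoxyphenyl on the amide-type nitrogen likewise depends on which bromo-methoxyphenyl group is present, giving a number 9.7 percentage points higher from compound 2 to compound 4 (within the scatter): the same change on two cores in this assay, a number 17.3 percentage points lower (beyond the scatter) from compound 1 to compound 3 and a number 9.7 percentage points higher (within the scatter) from compound 2 to compound 4, 27 percentage points apart, beyond the scatter of two such steps. Neither change therefore carries from one core to the other as a fixed step in these four compounds, though they do not show why the two changes fail to add up.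

The compounds shown leave open how an amine or a carboxylic acid in place of the bromine would read in this assay. They also leave open whether a longer chain on the amide-type nitrogen would show the same dependence.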